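Rearranging the Amine Chain of Compound 1

The source may report more compounds than this note shows. Statements on the series, on what has been measured and on what is new or still open speak of the compounds shown alone.

Compound 1, `O=c1cc(-c2ccccc2)oc2cc(O)c(OCCCCN3CCCC3)c(O)c12`, is one of three measured compounds. In a functional assay on HepG2 cells (Homo sapiens) for antiproliferative activity, read by MTT assay, with a stated time of 48 h (on this read-out lower numbers stand for stronger inhibition and higher numbers for weaker inhibition), compound 1 gives > 100000 nM, which is a limit of the assay and not a number. Compound 2, `COc1cc2oc(-c3ccccc3)cc(=O)c2c(O)c1OCCCCN1CCCC1`, gives 4900 nM. Compound 3, `O=c1cc(-c2ccccc2)oc2cc(OCc3ccccc3)c(OCCCCN3CCCC3)c(O)c12`, gives 2000 nM.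

Compound 1 thus stands only at a limit: the limit of > 100000 nM in this assay, at which 1 of the 3 values shown sits. Compound 4, `O=c1cc(-c2ccccc2)oc2cc(O)c(OCCCN3CCCCC3)c(O)c12`, differs from compound 1 in the amine end of the chain: piperidin-1-yl in place of (pyrrolidin-1-yl)methyl on a saturated chain carbon, three bonds along the chain from an oxygen on an aromatic ring.

The measured steps all change a different place, an oxygen on the aromatic ring. The step of an at least 20-fold lower number from compound 1 to compound 2 (1.30 log units; beyond the scatter) and the step of an at least 50-fold lower number from compound 1 to compound 3 (1.69 log units; beyond the scatter) are large, and the step of a 2.5-fold lower number from compound 2 to compound 3 (0.39 log units; beyond the scatter) is modest. None of them alters the amine or the chain carrying it, so none bears directly on the change from compound 1 to compound 4. Compound 4 keeps both free hydroxyls of compound 1, so compound 4 is expected to remain near the limit, with the step of a number no higher from compound 1 to compound 4 (the limit leaves the size open) estimated as none beyond the scatter. Compound 4 is therefore estimated at 100000 nM, within 30000 nM to 300000 nM.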

Compound 4, half-maximal inhibitory concentration: 70600 nM
Estimate against measurement, compound 4: 1.4-fold (0.15 log units) above, within the range that was stated.
By their numbers in this assay, from the lowest: compound 3; then compound 2; then compound 4. At a limit, above all of these: compound 1.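

The change from the 4-(pyrrolidin-1-yl)butyl chain to the 3-(piperidin-1-yl)propyl chain is the only one shown at the amine end, and in this assay it gives an at least 1.4-fold lower number from compound 1 to compound 4 (0.15 log units; that floor lies within the scatter). Compound 4 keeps both free hydroxyls and gives 70600 nM, so a change at the amine end alone can yield a measured number. The smallest size the step can have shows no gain beyond the scatter. The true size of the step stays open because compound 1 stands only at a limit, which is not a number: the limit of > 100000 nM in this assay, at which 1 of the 4 values shown sits.

Ring size and chain length change together in compound 4, so a 3-(pyrrolidin-1-yl)propyl chain would be needed to separate them. Also open, from the compounds shown here alone, is how a piperidin-1-yl or morpholine end would read with the methyl of compound 2 or the benzyl of compound 3 on the oxygen.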